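Trimming the Alkoxy Chain: From Compound 2 to Compound 3

The compounds below may be only part of what the source reports. "The series", "measured", "known", "first", "only" and "open" are said of these compounds alone.

Of the compounds shown here, two have been measured so far. Compound 1 `CCCCOc1ccc2c(Cl)ccnc2c1` gives 4130 nM in a functional assay on SK-OV-3 cells (Homo sapiens) for cytotoxicity, read by MTT assay, with a stated time of 48 h; on this read-out higher numbers stand for weaker inhibition and lower numbers for stronger inhibition. Compound 2 `CCCCCCCCOc1ccc2c(Cl)ccnc2c1` gives 4300 nM in this assay. Going by the values given here, the only step between them is a 1.0-fold higher number from compound 1 to compound 2 (0.02 log units; within the scatter), butyl in place of hydrogen on a saturated chain carbon, four bonds along the chain from an oxygen on an aromatic ring. On these two numbers compound 2 and compound 1 lie within the scatter of each other, so neither stands apart from the other.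

Compound 3 `CCCCCCOc1ccc2c(Cl)ccnc2c1` has not yet been measured in this assay. It differs from compound 2 by hydrogen in place of ethyl on a saturated chain carbon, six bonds along the chain from an oxygen on an aromatic ring. Among the compounds with values here, the one measured step that bears on this change is a 1.0-fold higher number from compound 1 to compound 2 (0.02 log units; within the scatter), which altered the same chain by a larger amount and left the number within the scatter. Compound 3 sits between compound 1 and compound 2 in chain length, and so the expected step of a 1.0-fold lower number from compound 2 to compound 3 (0.01 log units; within the scatter) is none beyond the scatter. Compound 3 is therefore estimated at 4200 nM, with a range from 2400 nM to 7500 nM.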

Compound 3, half-maximal inhibitory concentration: > 10000 nM
Compound 3: a limit, no number (the forecaster's own chance of this, stated with the estimate: 5%); at least 2.3-fold (0.37 log units) between middle value and limit.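

Compound 3 stands at a limit of the assay, not at a number, in this assay: the limit of > 10000 nM in this assay, at which 1 of the 3 values shown sits. Read against its neighbours in the series, this limit gives an at least 2.3-fold higher number from compound 2 to compound 3 (0.36 log units; beyond the scatter) and an at least 2.4-fold higher number from compound 1 to compound 3 (0.38 log units; beyond the scatter), both beyond the scatter, whereas the earlier pair had shown only a 1.0-fold higher number from compound 1 to compound 2 (0.02 log units; within the scatter), within the scatter. The chain therefore cannot be treated as a part that tolerates any change in length, and across these three compounds the numbers do not follow chain length in one direction: compound 3, whose chain is longer than that of compound 1 and shorter than that of compound 2, goes against the flat picture the first two compounds gave.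

On these data alone, how far the true number of compound 3 lies past the limit stays open, so the real size of both steps is unknown. Also open, as far as these compounds go, is whether a longer chain, a branched chain or an amine at the end of the chain would keep the number of compound 1 and compound 2 or lose it as compound 3 does.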